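The source may report more compounds than this note shows. Statements on the series, on what has been measured and on what is new or still open speak of the compounds shown alone.

For the measured compounds named here, compound 1 `CN(c1cccc(C#Cc2cc(Cl)ccc2OCC(=O)O)c1)S(C)(=O)=O` gives 122 nM in an assay on CHO cells for displacement of a labelled ligand from prostaglandin D2 receptor 2 (Homo sapiens), read by scintillation counting (on this read-out lower numbers stand for stronger inhibition and higher numbers for weaker inhibition), the higher of the two numbers measured so far. Compound 2 `N#Cc1ccc(OCC(=O)O)c(C#Cc2ccccc2Cl)c1` gives 24 nM in this assay; the two structures differ in more than one place, so the gap only shows compound 2 sitting well below compound 1. Compound 3 `CN(C)S(=O)(=O)c1cccc(C#Cc2cc(Cl)ccc2OCC(=O)O)c1` is not yet measured; it differs from compound 1 by dimethylsulfamoyl in place of methyl(methylsulfonyl)amino on an aromatic carbon, the same atoms joined differently. Going by the values given here, no measured pair covers such a reversal, so the expected step of a 1.1-fold lower number from compound 1 to compound 3 (0.04 log units; within the scatter) is within the scatter, with no direction called. Compound 3 is estimated at 110 nM, between 35 nM and 350 nM.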

Compound 3, inhibition constant: 14 nM
Compound 3: middle estimate off by 7.9-fold (0.90 log units), on the high side, and the stated range ends above it.
By their numbers in this assay, from the lowest: compounds 3 and 2 (each within the scatter of the next); then compound 1.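

At this position, on an aromatic carbon meta to a large group, the way the atoms are joined matters and not only which atoms are present: dimethylsulfamoyl in place of methyl(methylsulfonyl)amino gives an 8.7-fold lower number from compound 1 to compound 3 (0.94 log units; beyond the scatter) in this assay. The two groups have the same heavy atoms, hydrogen-bond acceptors and net charge. No measurement on hand accounts for the step. As far as these compounds go, whether a sulfamoyl group without methyl groups, or a morpholine-4-sulfonyl group, stays close to compound 3 remains open, since this single pair defines no trend at this position.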